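From 4-methoxyphenyl to 3,4-dihydroxyphenyl: working notes

The source may hold more compounds than are shown below. What is called first, only, known or untested is meant among the compounds shown, and "the series" means these compounds.

Values in a physicochemical assay, read by spectrophotometry, with a stated time of 15 min; a higher number here means a weaker inhibitor, a lower number a stronger inhibitor:
- compound 1 `O=C(CCCc1nc2ccccc2c(=O)[nH]1)N/N=C/c1cc(O)c(O)c(O)c1`: 45000000 nM
- compound 2 `COc1cc(/C=N/NC(=O)CCCc2nc3ccccc3c(=O)[nH]2)ccc1O`: 280000000 nM
- compound 3 `COc1ccc(/C=N/NC(=O)CCCc2nc3ccccc3c(=O)[nH]2)cc1`: 280000000 nM

Compound 3 stands level with compound 2, with no change at the digits printed from compound 2 to compound 3 (within the scatter), and the numbers of both exceed that of compound 1. The next compound is compound 4 `O=C(CCCc1nc2ccccc2c(=O)[nH]1)N/N=C/c1ccc(O)c(O)c1`, which carries 3,4-dihydroxyphenyl in place of 4-methoxyphenyl on a carbon with a double bond to nitrogen.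

Two modest steps bear on this change: a 6.2-fold higher number from compound 1 to compound 3 (0.79 log units; beyond the scatter) and a 6.2-fold higher number from compound 1 to compound 2 (0.79 log units; beyond the scatter). Both start from the 3,4,5-trihydroxyphenyl group, the measured group closest in name to the incoming one. A lower number in this assay is therefore expected, of similar size or somewhat smaller. The expected step is a 3.1-fold lower number from compound 3 to compound 4 (0.49 log units; beyond the scatter). The estimate for compound 4 is 90000000 nM, with an expected range of 35000000 nM to 280000000 nM.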

Compound 4, half-maximal inhibitory concentration: 75000000 nM
For compound 4 the middle estimate is 1.2-fold (0.08 log units) above the measured one, within the range that was stated.
By their numbers in this assay, from the lowest: compounds 1 and 4 (each within the scatter of the next); then compounds 2 and 3 (each within the scatter of the next).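

In this assay hydrogen in place of methyl on an oxygen on an aromatic ring gives a 3.7-fold lower number from compound 2 to compound 4 (0.57 log units; beyond the scatter) and 3,4-dihydroxyphenyl in place of 4-methoxyphenyl gives a 3.7-fold lower number from compound 3 to compound 4 (0.57 log units; beyond the scatter) as well. Hydrogen in place of hydroxy on an aromatic carbon gives a 1.7-fold higher number from compound 1 to compound 4 (0.22 log units; within the scatter) and stays within the scatter, so the third hydroxy of the 3,4,5-trihydroxyphenyl group is not needed to hold this level.

Open, on these data alone, is whether a 4-hydroxyphenyl group, or an amine or carboxylic acid on the ring, would hold the number of compound 4. Nothing measured here gives a reason for these steps.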